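The compounds below may be only part of what the source reports. "The series", "measured", "known", "first", "only" and "open" are said of these compounds alone.

Working notes on the series. Compound 1 `Oc1cccc(-c2cc(-c3cccs3)cc(-c3ccccc3O)n2)c1` and compound 2 `Oc1cccc(-c2cc(-c3ccco3)cc(-c3ccccc3O)n2)c1` share a core carrying a 2-hydroxyphenyl group and a 3-hydroxyphenyl group, and differ only in the third substituent. In an assay on isolated protein for inhibition of DNA topoisomerase 1 (Homo sapiens), with a stated time of 30 min, tested at 20 uM (on this read-out higher numbers stand for a stronger effect at the one concentration tested and lower numbers for a weaker effect), compound 1 gives 1.5%, and compound 2 gives 0% in this assay. Among the compounds with values here, the one measured step, a number 1.5 percentage points lower from compound 1 to compound 2 (within the scatter), therefore shows that exchanging one five-membered heteroaryl group for another in this position leaves the read-out essentially unchanged, both results sitting close to the bottom of the scale.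

Compound 3 `Oc1cccc(-c2cc(-c3ccoc3)cc(-c3ccccc3O)n2)c1` carries a furan-3-yl group in the same position. In this assay compound 3 gives "not determined" (no result reported), so it has no number to stand on; its place in the series rests on its structure alone, which sits between compound 2 and the next member.

Compound 4 `Oc1cccc(-c2cc(-c3ccccn3)cc(-c3ccccc3O)n2)c1` differs from compound 3 by pyridin-2-yl in place of furan-3-yl on an aromatic carbon. Within the data shown here, no measured step covers a six-membered heteroaryl group in this position, so nothing bears on it directly; the only step available, from compound 1 to compound 2, is within the scatter. By that reasoning no step beyond the scatter is expected for compound 4 in this assay, and compound 4 is expected to give about 2%, within a range of 0% to 12%.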

Compound 4, a percentage reported as inhibition, at one concentration (the size of the read-out at that concentration, not a potency): 0.1%
Compound 4: the middle estimate sits 1.9 percentage points above what was measured; low and high end bracket the measured number.
By their numbers in this assay, from the lowest: compounds 2, 4 and 1 (each within the scatter of the next).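

With pyridin-2-yl, this assay now covers a six-membered aromatic ring opposite the ring nitrogen, where the earlier numbers covered only five-membered rings, and the steps to it are a number 0.1 percentage points higher from compound 2 to compound 4 (within the scatter) and a number 1.4 percentage points lower from compound 1 to compound 4 (within the scatter), so thiophen-2-yl, furan-2-yl and pyridin-2-yl cannot be told apart in this position. The change in ring size, and the change from a sulfur or oxygen hetero atom to a ring nitrogen, therefore give no step beyond the scatter across compound 1, compound 2 and compound 4, while any step to or from compound 3 cannot be read. No evidence at hand bears on why the read-out stays flat across these groups.

As far as these compounds go, all three numbers lie near the bottom of the scale at a single concentration, so it remains open whether any group in this position can lift the read-out beyond the scatter, for instance an amine, a carboxylic acid or a longer alkyl chain. The contribution of the 2-hydroxyphenyl and 3-hydroxyphenyl groups is also open, as neither is varied in the compounds shown.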